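Trifluoromethyl to hydrogen: the step from compound 3 to compound 4

The source may hold more compounds than are shown below. What is called first, only, known or untested is meant among the compounds shown, and "the series" means these compounds.

Compound 3 `COc1cc(Cl)cc(-c2nn(-c3cccc(NC(=O)Nc4cc(C(F)(F)F)cc(C(F)(F)F)c4)c3)cc2-c2ccncc2)c1` gives 92% in a functional assay on Malme-3M cells (Homo sapiens) for inhibition, read by sulforhodamine B assay, with a stated time of 48 h, tested at 0.01 uM (a higher number here means a weaker effect of the compound at the concentration tested, a lower number a stronger effect), the second highest of three numbers. Compound 1 `O=C(Nc1cccc(-n2cc(-c3ccncc3)c(-c3cc(O)cc(Cl)c3)n2)c1)Nc1ccc(Cl)c(C(F)(F)F)c1` gives 93%, within the scatter of compound 3, while compound 2 `O=C(Nc1cccc(-n2cc(-c3ccncc3)c(-c3cc(O)cc(Cl)c3)n2)c1)Nc1ccc(Cl)c(Cl)c1` gives 57%, beyond the scatter below it. Compound 4 `COc1cc(Cl)cc(-c2nn(-c3cccc(NC(=O)Nc4cccc(C(F)(F)F)c4)c3)cc2-c2ccncc2)c1` differs from compound 3 by hydrogen in place of trifluoromethyl on an aromatic carbon. Among the measured compounds shown here, one measured step bears on this change: a number 36 percentage points lower from compound 1 to compound 2 (beyond the scatter), where a trifluoromethyl also left an aromatic carbon, though chloro rather than hydrogen took its place. For the measured compounds named here, a downward step beyond the scatter is therefore expected for compound 4, its size uncertain because no measured step swaps trifluoromethyl for hydrogen. Compound 4 is estimated at 68%, range 45% to 92%, an expected step of a number 24 percentage points lower from compound 3 to compound 4 (beyond the scatter).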

Compound 4, a percentage reported as activity, at one concentration (the size of the read-out at that concentration, not a potency): 95%
Compound 4: middle estimate off by 27 percentage points, on the low side; the whole stated range lies below it.
By their numbers in this assay, from the lowest: compound 2; then compounds 3, 1 and 4 (each within the scatter of the next).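

In this assay, hydrogen in place of trifluoromethyl at this place gives a number 3 percentage points higher from compound 3 to compound 4 (within the scatter), so this trifluoromethyl can leave the aromatic carbon with no change in the read-out beyond the scatter. Loss of a trifluoromethyl from an aromatic carbon therefore does not on its own go with a drop like a number 36 percentage points lower from compound 1 to compound 2 (beyond the scatter). No measurement on hand explains this flat step.

Open, as far as these compounds go, is whether an amine or a carboxylic acid at this place would keep the number near that of compound 4, and whether chloro here would lower it.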